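Swapping a pivaloyl amide for a chromane sulfonamide

This account rests on a few compounds, and the source may have more. Where it says the series, first, only, none or still open, it means among the compounds named here.

The series shares a thiazole-bearing core carrying a diaryl ether. Compound 1 `Cc1cc(Br)cc(OC(c2ccc(Cl)cc2)c2cnc(NC(=O)OC(C)(C)C)s2)c1` and compound 2 `CC(C)(C)C(=O)Nc1ncc(C(Oc2ccc3cc(Br)ccc3c2)c2ccc(Cl)cc2)s1` have both been tested in an ADME assay on HepG2 2.2.15 cells (Homo sapiens) for cytotoxicity; on this read-out higher numbers stand for lower toxicity in this test and lower numbers for higher toxicity in this test. In this assay compound 1 gives > 50000 nM, which is a limit of the test rather than a measured number. Compound 2 is reported only as "not toxic" (no number reported) in this assay, with no figure attached, so where compound 2 stands can be said only in words: it sits alongside the other entry, where the limit of > 50000 nM in this assay, at which 1 of the 2 values shown sits, marks the upper boundary of what the test reports.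

Compound 3 `O=S(=O)(Nc1ncc(C(Oc2ccc3cc(Br)ccc3c2)c2ccc(Cl)cc2)s1)c1ccc2c(c1)CCO2` has not yet been measured in this assay. It is derived from compound 2 by the change (a group of 12 heavy atoms (8 carbon, 3 oxygen, 1 sulfur; one five-membered non-aromatic ring with 1 hetero atom, one six-membered aromatic ring of carbon only) in place of a group of 6 heavy atoms (5 carbon, 1 oxygen; no ring), on a nitrogen on an aromatic ring). Among the compounds with values here, no measured step within this set separates two numbered values, so no size of effect can be taken from the data. Given that compound 2 is "not toxic" (no number reported) in this assay, a shift in either direction that exceeds the usual scatter is not expected. Compound 3 is therefore estimated at 50000 nM, within a range from 20000 nM to 100000 nM.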

Compound 3, half-maximal cytotoxic concentration: > 50000 nM
Compound 3 gave a limit, no number; the forecaster's own chance of this, stated with the estimate: 70%; the middle value lies on the limit itself.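

Compound 2 and compound 3 both lack a single number in this assay, and no step can be read between them. Compound 3 gives > 50000 nM, which is a limit. The compounds shown leave open whether exchanging the group on the nitrogen changes the read-out at all, and at what concentration any of them would turn toxic in this assay.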